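The source may hold more compounds than are shown below. What is called first, only, known or untested is meant among the compounds shown, and "the series" means these compounds.

Measured so far:
- compound 1 `Nc1nccc(-c2ccc3nc(C4COc5ccc(F)cc5C4)oc3c2)n1`: 15 nM
- compound 2 `COc1ccc2c(c1)CC(c1nc3ccc(-c4ccnc(N)n4)cc3[nH]1)CO2`: 2 nM

In an assay on isolated protein for inhibition of Rho-associated protein kinase 2 (Homo sapiens) (on this read-out lower numbers stand for stronger inhibition and higher numbers for weaker inhibition), compound 1 gives 15 nM, the higher of the two numbers; compound 2, which differs from it in several places at once, gives 2 nM, a gap beyond the scatter. Compound 3 `COC(=O)c1ccc2c(c1)CC(c1nc3ccc(-c4ccnc(N)n4)cc3o1)CO2` is not yet measured. It differs from compound 1 in one place: methoxycarbonyl in place of fluoro on an aromatic carbon. Among the measured compounds shown here, no measured pair shows this change, so there is no step to lean on, and the expectation from compound 1 is no step beyond the scatter, no change at the digits printed from compound 1 to compound 3 (within the scatter). Compound 3 is therefore estimated at 15 nM, between 5 nM and 45 nM.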

Compound 3, half-maximal inhibitory concentration: 24 nM
Compound 3: the middle estimate sits 1.6-fold (0.20 log units) below what was measured; the measured number falls inside the stated range.
By their numbers in this assay, from the lowest: compound 2; then compounds 1 and 3 (each within the scatter of the next).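

In this assay, replacing fluoro with methoxycarbonyl on this aromatic carbon gives a 1.6-fold higher number from compound 1 to compound 3 (0.20 log units; within the scatter) and stays within the scatter. For this one pair, four heavy atoms with two hydrogen-bond acceptors can therefore stand where a single fluorine stood, with no readable change in inhibition. Nothing in the available data gives a reason for this. From the compounds shown here alone, whether a carboxylic acid or an amine on the same aromatic carbon would also leave the number unchanged remains open. One pair also cannot show whether this holds on other cores.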